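Pyrazole N-methyl removal: expected effect on solubility

The source may hold more compounds than are shown below. What is called first, only, known or untested is meant among the compounds shown, and "the series" means these compounds.

Two members of this series carry a measured value. Compound 1 `Cc1nn(-c2cccc3cc(Cc4cccc(C(F)(F)F)c4)sc23)c(C)c1C(=O)NCCO` gives 12 ug/mL in a physicochemical assay for solubility, read by HPLC, at pH 6.8; on this read-out higher numbers stand for higher solubility and lower numbers for lower solubility. Compound 2 `COCCNC(=O)c1cnn(-c2cccc3cc(Cc4cccc(C(F)(F)F)c4)sc23)c1C` gives 1.3 ug/mL in this assay, the lowest of the two numbers; its nearest neighbour is compound 1, which gives a number higher by an amount beyond the usual scatter. Going by the values given here, compound 1 and compound 2 differ in more than one place, so no single step between them is drawn and only their two values are taken as they stand.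

Compound 3 `COCCNC(=O)c1cnn(-c2cccc3cc(Cc4cccc(C(F)(F)F)c4)sc23)c1` is the next member to be measured. Relative to compound 2 its change is hydrogen in place of methyl on an aromatic carbon. Among the compounds with values here, no measured step of this kind exists, so the expectation rests on the single value of compound 2 and on the small size of the change, which removes one heavy atom and no donor or acceptor. A step within the usual scatter is expected, if anything a slight rise. For compound 3 the estimated step from compound 2 is a 1.5-fold higher number from compound 2 to compound 3 (0.19 log units; within the scatter). Compound 3 is therefore expected to give about 2 ug/mL in this assay, within a range from 0.7 ug/mL to 6 ug/mL.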

Compound 3, solubility: < 0.08 ug/mL
Compound 3: only a limit was reported; the forecaster's own chance of this, stated with the estimate: 5%; middle value at least 25-fold (1.39 log units) away from the limit.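

In this assay, hydrogen in place of methyl gives an at least 16-fold lower number from compound 2 to compound 3 (1.21 log units; beyond the scatter), so the read-out is sensitive to this one aromatic carbon, next to the ring nitrogen and next to the ring atom that bears the (2-methoxyethyl)carbamoyl group. Going by these compounds alone, compound 1 and compound 2 differ in more than one place and gave no single step, whereas this pair isolates a change of one carbon, with no hydrogen-bond donor or acceptor leaving or entering, and that change alone produces a large step. Compound 3 is reported only as a limit, so the step has a minimum size and no known full size: the limit of < 0.08 ug/mL in this assay, at which 1 of the 3 values shown sits.

On these data alone, whether an ethyl group or a chlorine atom on this carbon would read like the methyl of compound 2 or like the hydrogen of compound 3 remains open. Also open is whether the same change would give a step of similar size with the amide side chain and second ring methyl of compound 1, since the compounds shown hold no pair that tests this.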